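The source may hold more compounds than are shown below. What is called first, only, known or untested is meant among the compounds shown, and "the series" means these compounds.

Measured so far:
compound 1, `Nc1scc(CN2CCN(c3ccc(Cl)cc3F)CC2)c1C(=O)c1ccc(Cl)cc1` — 1%
compound 2, `Nc1scc(CN2CCN(c3cc(F)cc(F)c3)CC2)c1C(=O)c1ccc(Cl)cc1` — 2%

Both numbers come from an assay on CHO cells for displacement of a labelled ligand from adenosine receptor A3 (Homo sapiens), read by scintillation counting, with a stated time of 120 min, tested at 10 uM; a lower number here means less inhibition, a higher number more inhibition at the concentration tested (going by the name of the read-out). Compound 1 gives 1% and compound 2 gives 2%; the two lie within the scatter of each other, so compound 2 cannot be placed above compound 1, only beside it, with both showing little inhibition. Among the compounds with values here, the one measured step, a number 1 percentage points higher from compound 1 to compound 2 (within the scatter), shows that swapping the aryl group on the ring amine nitrogen left the read-out where it was.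

Compound 3, `Nc1scc(CN2CCN(c3cccc(F)c3F)CC2)c1C(=O)c1ccc(Cl)cc1`, is not yet measured. Its change from compound 2 is 2,3-difluorophenyl in place of 3,5-difluorophenyl on an amine nitrogen in a ring. This is a change of the same kind and at the same place as the step from compound 1 to compound 2, which stayed within the scatter, and nothing else in the two compounds differs.

The expectation is therefore that the step of a number 1 percentage points higher from compound 2 to compound 3 (within the scatter) will not go beyond the scatter. Compound 3 is estimated to give 3% in this assay, within a range of -8% to 15%.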

Compound 3, a percentage reported as inhibition, at one concentration (the size of the read-out at that concentration, not a potency): 0%
Beside the measured number, compound 3's estimate is 3 percentage points above it, within the range that was stated.
By their numbers in this assay, from the lowest: compounds 3, 1 and 2 (each within the scatter of the next).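

In this assay, rearranging the same atoms on the phenyl group at the ring amine nitrogen gives the step of a number 2 percentage points lower from compound 2 to compound 3 (within the scatter) with no difference in heavy atoms or hydrogen-bond counts between 3,5-difluorophenyl and 2,3-difluorophenyl. The step of a number 1 percentage points lower from compound 1 to compound 3 (within the scatter) reads the same way, so 4-chloro-2-fluorophenyl, 3,5-difluorophenyl and 2,3-difluorophenyl all stand together at little inhibition, and no halogen pattern among these three separates from another at this position. Nothing measured here accounts for this flat picture.

Open, from the compounds shown here alone, is whether any group on this nitrogen lifts the read-out in this assay clear of this low level, for instance a phenyl carrying a methoxy group, an amine or a carboxylic acid rather than halogens alone. Also open is whether the read-out answers at all to a change elsewhere on the shared core, since all the compounds shown differ only in this one aryl group and all sit so low that a real difference between them could not be seen.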